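The source may report more compounds than this note shows. Statements on the series, on what has been measured and on what is new or still open speak of the compounds shown alone.

Measured so far:
Compound 1 `Cc1ccc(NC(=S)N/N=C2\C(=O)N(Cc3ccc(F)cc3)c3ccc(Br)cc32)cc1` — 57000 nM
Compound 2 `Cc1ccc(NC(=S)N/N=C2\C(=O)N(Cc3ccc(Cl)cc3)c3ccc(Br)cc32)cc1` — 288000 nM

In a functional assay on MOLT-4 cells (Homo sapiens), with a stated time of 72 h (a higher number here means a weaker inhibitor, a lower number a stronger inhibitor), compound 1 gives 57000 nM and compound 2 gives 288000 nM, the highest of the two numbers shown. Among the measured compounds shown here, the only step known is a 5.1-fold higher number from compound 1 to compound 2 (0.70 log units; beyond the scatter), which shows the ring position in question is sensitive. Compound 3 `Cc1ccc(CN2C(=O)/C(=N\NC(=S)Nc3ccc(C)cc3)c3cc(Br)ccc32)cc1` differs from compound 2 by methyl in place of chloro on an aromatic carbon. For the measured compounds named here, no measured step bears directly on exchanging chloro for methyl, so compound 3 is expected to stay near compound 2, with the change a 1.4-fold lower number from compound 2 to compound 3 (0.16 log units; within the scatter) carrying wide uncertainty. Compound 3 is estimated at 200000 nM, between 60000 nM and 700000 nM.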

Compound 3, half-maximal inhibitory concentration: 393000 nM
Compound 3: the middle estimate sits 2.0-fold (0.29 log units) below what was measured, and the stated range covers the measured number.
By their numbers in this assay, from the lowest: compound 1; then compounds 2 and 3 (each within the scatter of the next).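

In this assay the exchange of chloro for methyl gives no change beyond the scatter (a 1.4-fold higher number from compound 2 to compound 3 (0.14 log units; within the scatter)), so the 4-chlorobenzyl and 4-methylbenzyl groups cannot be told apart here. Methyl, like chloro, stands clearly apart from fluoro (a 6.9-fold higher number from compound 1 to compound 3 (0.84 log units; beyond the scatter)), which leaves fluoro alone with the lower number among these three compounds. Nothing available here explains this result.
What the compounds shown leave open is how a methoxy group, an amine or plain hydrogen would read at this carbon. From the compounds shown here alone, it also remains open whether the gap from fluoro persists when the bromo group on the core is replaced.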